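The source may report more compounds than this note shows. Statements on the series, on what has been measured and on what is new or still open speak of the compounds shown alone.

Measured so far:
compound 1, `CCCn1c(=O)c2nc(C3CCCC(N)C3)[nH]c2n(CCC)c1=O`, 50 nM in a functional assay for antagonist activity at adenosine receptor A1 (Homo sapiens); on this read-out higher numbers stand for weaker inhibition and lower numbers for stronger inhibition;
compound 2, `CCCn1c(=O)c2nc(C3=C(C(=O)O)CCC3)[nH]c2n(CCC)c1=O`, which in this assay reaches only the assay limit of > 10000 nM;
compound 3, `CCCn1c(=O)c2nc(C3CCC3C(=O)O)[nH]c2n(CCC)c1=O`, 660 nM in this assay.

Compound 3 therefore stands highest of the two compounds with a number; its nearest neighbour is compound 1, and the step of a 13-fold higher number from compound 1 to compound 3 (1.12 log units; beyond the scatter) was large. The limit of compound 2 is recorded in the limit of > 10000 nM in this assay, at which 1 of the 3 values shown sits.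

Compound 4 is `CCCn1c(=O)c2nc(NC3CCCC3)[nH]c2n(CCC)c1=O` and has not yet been measured in this assay. It differs from compound 3 in one place: cyclopentylamino in place of 2-carboxycyclobutyl on an aromatic carbon. Among the measured compounds shown here, two measured steps bear on this change, both involving exchange of a carboxylated ring on the same aromatic carbon of the shared core: a 13-fold higher number from compound 1 to compound 3 (1.12 log units; beyond the scatter) and an at least 15-fold lower number from compound 2 to compound 3 (1.18 log units; beyond the scatter). Both were large, and both placed the compounds without the carboxycyclopentenyl or carboxycyclobutyl group at the lower number. Compound 4 carries neither carboxylated ring, so a lower number is expected, a step of a 17-fold lower number from compound 3 to compound 4 (1.22 log units; beyond the scatter). Compound 4 is estimated at 40 nM, within a range from 5 nM to 300 nM.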

Compound 4, inhibition constant: 8 nM
The estimate for compound 4 lay 5.0-fold (0.70 log units) above the measured number; low and high end bracket the measured number.
By their numbers in this assay, from the lowest: compound 4; then compound 1; then compound 3. At a limit, above all of these: compound 2.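

In this assay, cyclopentylamino on this aromatic carbon gives the lowest number among the compounds shown, and the exchange for 2-carboxycyclobutyl proved larger than any earlier step to a measured number: an 83-fold lower number from compound 3 to compound 4 (1.92 log units; beyond the scatter). Among the compounds shown here, the step of an at least 1200-fold lower number from compound 2 to compound 4 (3.09 log units; beyond the scatter) is read against a limit of the assay, the one held by compound 2. The 3-aminocyclohexyl group also carries no carboxylic acid, yet replacing it still gave a 6.3-fold lower number from compound 1 to compound 4 (0.80 log units; beyond the scatter), so the absence of the acid does not alone set the number at this position.

Going by these compounds, it remains open whether the linking amine nitrogen or the five-membered ring accounts for the result, and a plain cyclopentyl group on this carbon would separate the two. On these data alone, how a cyclohexylamino group or a longer chain on that nitrogen would read also remains open.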